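A few compounds are considered here, and "the series" means these few. Any claim that something is new, unique, unknown or untested is made for them only; others in the source may bear on it.

Of the compounds shown here, three built on one shared core have been tested in a functional assay on MCF7 cells (Homo sapiens) for antiproliferative activity, read by MTT assay, with a stated time of 48 h; on this read-out lower numbers stand for stronger inhibition and higher numbers for weaker inhibition. Compound 1 `O=C(/C=C/c1cccc(NC(=O)c2ccccc2Br)c1)c1nc2ccccc2[nH]1` gives 4520 nM. Compound 2 `Cc1ccccc1C(=O)Nc1cccc(/C=C/C(=O)c2nc3ccccc3[nH]2)c1` gives 5870 nM, and compound 3 `O=C(/C=C/c1cccc(NS(=O)(=O)c2cccc(Cl)c2)c1)c1nc2ccccc2[nH]1` gives 4160 nM. Compound 2 carries the highest number of the three, yet its gaps to the other two are within the scatter, a 1.3-fold higher number from compound 1 to compound 2 (0.11 log units; within the scatter) and a 1.4-fold lower number from compound 2 to compound 3 (0.15 log units; within the scatter), so the three cannot be told apart on these numbers.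

Compound 4 `Cc1cccc(S(=O)(=O)Nc2cccc(/C=C/C(=O)c3nc4ccccc4[nH]3)c2)c1` has not yet been measured. It differs from compound 2 in one place: (3-methylphenyl)sulfonyl in place of (2-methylphenyl)carbonyl on a nitrogen on an aromatic ring. The nearest measured step also replaces the same carbonyl group with a sulfonyl group, a 1.4-fold lower number from compound 2 to compound 3 (0.15 log units; within the scatter); the related replacement a 1.1-fold lower number from compound 1 to compound 3 (0.04 log units; within the scatter) is also within the scatter, and the swap of bromo for methyl, a 1.3-fold higher number from compound 1 to compound 2 (0.11 log units; within the scatter), is within the scatter too. Nothing here points to a step beyond the scatter, so for compound 4 the expected step in this assay is a 1.3-fold lower number from compound 2 to compound 4 (0.11 log units; within the scatter). The estimate for compound 4 is 4600 nM, with a range from 2300 nM to 9200 nM.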

Compound 4, half-maximal inhibitory concentration: 886 nM
Compound 4: the middle estimate sits 5.2-fold (0.72 log units) above what was measured; measured number below the stated range.
By their numbers in this assay, from the lowest: compound 4; then compounds 3, 1 and 2 (each within the scatter of the next).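

The place on the nitrogen turns out to be sensitive in this assay: (3-methylphenyl)sulfonyl gives a clear gain over the (2-methylphenyl)carbonyl of compound 2 (a 6.6-fold lower number from compound 2 to compound 4 (0.82 log units; beyond the scatter)) and over the (2-bromophenyl)carbonyl of compound 1 (a 5.1-fold lower number from compound 1 to compound 4 (0.71 log units; beyond the scatter)). The sulfonyl link alone does not account for this, as compound 3 also carries it and stays within the scatter of compounds 1 and 2, while methyl in place of chloro on that ring gives a step of similar size (a 4.7-fold lower number from compound 3 to compound 4 (0.67 log units; beyond the scatter)). Nothing available here explains the gain.

On these data alone, it remains open whether the gain is specific to methyl, or whether a methoxy group or an amine on the same ring would give a similar number. Also open, as far as these compounds go, is whether (3-methylphenyl)carbonyl on the same nitrogen would read like compound 2 or like compound 4.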